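The source may report more compounds than this note shows. Statements on the series, on what has been measured and on what is new or still open speak of the compounds shown alone.

The shared core appears in compound 1 `O=C1O[C@H]([C@@H](O)Cn2cc(CNS(=O)(=O)c3ccc(Cl)cc3F)nn2)C(OCc2ccccc2)=C1OCc1ccccc1`, compound 2 `O=C1O[C@H]([C@@H](O)Cn2cc(CNS(=O)(=O)c3ccc(F)cc3)nn2)C(OCc2ccccc2)=C1OCc1ccccc1` and compound 3 `O=C1O/C(=C\Cn2cc(-c3cccc(O)c3)nn2)C(OCc2ccccc2)=C1OCc1ccccc1`, all tested in a functional assay on HepG2 cells (Homo sapiens) for antiproliferative activity, read by MTT assay, with a stated time of 72 h; a lower number here means a stronger inhibitor, a higher number a weaker inhibitor. Compound 1 gives 25500 nM, compound 2 gives 18300 nM and compound 3 gives 61700 nM. Compound 2 holds the lowest number of the three; compound 1 sits within the scatter of it, while compound 3 lies beyond the scatter. Among the measured compounds shown here, the single one-place step measured so far, a 1.4-fold lower number from compound 1 to compound 2 (0.14 log units; within the scatter), stays within the scatter.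

Compound 4 `Cc1ccc(-c2cn(C[C@H](O)[C@H]3OC(=O)C(OCc4ccccc4)=C3OCc3ccccc3)nn2)cc1` awaits measurement. It differs from compound 2 in one place: 4-methylphenyl in place of (((4-fluorophenyl)sulfonyl)amino)methyl on an aromatic carbon. For the measured compounds named here, no measured step covers this change; the one step available alters only the ring on the sulfonyl sulfur and says nothing about exchanging the whole group. Compound 3 also bears a six-membered aromatic ring of carbon only on the five-membered aromatic ring with 3 nitrogen, yet it differs from compound 2 elsewhere too. The value of compound 3, 61700 nM, is only a loose pointer toward a higher number. For compound 4 the expected step is a 1.9-fold higher number from compound 2 to compound 4 (0.28 log units; within the scatter), judged modest but beyond the scatter. The estimate for compound 4 is 35000 nM, expected to fall between 12000 nM and 100000 nM.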

Compound 4, half-maximal inhibitory concentration: 8770 nM
Beside the measured number, compound 4's estimate is 4.0-fold (0.60 log units) above it, and the stated range ends above it.
By their numbers in this assay, from the lowest: compound 4; then compounds 2 and 1 (each within the scatter of the next); then compound 3.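

At the aromatic carbon of the five-membered aromatic ring with 3 nitrogen, replacing the whole (((4-fluorophenyl)sulfonyl)amino)methyl group with 4-methylphenyl in this assay gives a 2.1-fold lower number from compound 2 to compound 4 (0.32 log units; beyond the scatter) and so moves the number beyond the scatter, which the earlier change on the sulfonyl sulfur did not do. The entering group has fewer heavy atoms and no hydrogen-bond donors or acceptors, so on this core the activity seen does not depend on keeping the sulfonyl and amino atoms at this position. No measured evidence bears on why the number falls.

Open, going by these compounds, is how a plain phenyl, an amine or a carboxylic acid on this aromatic carbon would compare with 4-methylphenyl. Also open, on these data alone, is whether the same exchange would lower the number on the core of compound 3, which differs elsewhere.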